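The source may report more compounds than this note shows. Statements on the series, on what has been measured and on what is new or still open speak of the compounds shown alone.

In a functional assay on CHO cells for agonist activity at Free fatty acid receptor 1 (Homo sapiens), read by a luciferase reporter (on this read-out higher numbers stand for larger maximal responses and lower numbers for smaller maximal responses), compound 1 `O=C(O)COc1ccc(NCc2cccc(Oc3ccccc3)c2)cc1` gives 84% and compound 2 `O=C(O)CSc1ccc(NCc2cccc(Oc3ccccc3)c2)cc1` gives 84%. Going by the values given here, the one step measured so far is no change at the digits printed from compound 1 to compound 2 (within the scatter). Compound 2 therefore stands level with compound 1 at the digits shown, and nothing else in the series has been measured.

Compound 3 `CC(CC(=O)O)c1ccc(NCc2cccc(Oc3ccccc3)c2)cc1` is not yet measured; it differs from compound 2 by 1-(carboxymethyl)ethyl in place of (carboxymethyl)sulfanyl on an aromatic carbon. Among the compounds with values here, only the step from compound 1 to compound 2 bears on this, and only loosely: that step put (carboxymethyl)sulfanyl in place of carboxymethoxy, whereas here 1-(carboxymethyl)ethyl enters, a change no measured pair tests. Because no change at the digits printed from compound 1 to compound 2 (within the scatter) left the maximal response where it was, the step expected here, a number 4 percentage points lower from compound 2 to compound 3 (within the scatter), is none beyond the scatter, though with wide uncertainty. Compound 3 is expected to give about 80%, in the range 55% to 98%.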

Compound 3, largest response reached (reported as percent of maximum), in percent of the reference or control that the assay uses: 83%
Compound 3: middle estimate off by 3 percentage points, on the low side; the range from low to high includes it.
By their numbers in this assay, from the lowest: compounds 3, 1 and 2 (each within the scatter of the next).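

Within the three compounds, the link between the aromatic carbon and the acid chain can be carbon as well as oxygen or sulfur: in this assay, 1-(carboxymethyl)ethyl in place of (carboxymethyl)sulfanyl gives a number 1 percentage points lower from compound 2 to compound 3 (within the scatter), and in place of carboxymethoxy it gives a number 1 percentage points lower from compound 1 to compound 3 (within the scatter). This position, para to a large group, therefore keeps its maximal response with a branched carbon chain, a change that the step between the oxygen and sulfur links did not test. No measurement given here accounts for this lack of separation.

Still open, as far as these compounds go, is whether the response holds with an amine as the link, or with a longer chain between the aromatic carbon and the carboxylic acid. Also open, from the compounds shown here alone, is whether a tetrazole can stand in place of the carboxylic acid.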